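Thiazolyl-aniline series: ethoxy to methyl on the aryl ring

The source may report more compounds than this note shows. Statements on the series, on what has been measured and on what is new or still open speak of the compounds shown alone.

Measured so far in an assay on isolated protein for inhibition of Polyunsaturated fatty acid 5-lipoxygenase (Homo sapiens), read by HPLC, with stated times of 15 min and 10 min; on this read-out higher numbers stand for weaker inhibition and lower numbers for stronger inhibition:
compound 1 `CCOc1ccc(-c2csc(Nc3ccc(O)cc3)n2)cc1` gives 30 nM
compound 2 `COc1ccc(Nc2nc(-c3ccc(Cl)cc3)cs2)cc1OC` gives 400 nM
compound 3 `Oc1ccc(-c2csc(Nc3ccc(Cl)cc3)n2)cc1` gives 500 nM

Compound 1 stands lowest of the three numbers; compound 2 is the nearest to it and compound 3 the furthest, and both gaps are beyond the scatter, so compound 1 is the strongest inhibitor measured here. Going by the values given here, neither compound 2 nor compound 3 differs from compound 1 in one place only, so no measured single step exists to lean on.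

Compound 4 `Cc1ccc(-c2csc(Nc3ccc(O)cc3)n2)cc1` is not yet measured. It differs from compound 1 by methyl in place of ethoxy on an aromatic carbon. Methyl in place of ethoxy on an aromatic carbon is the whole change; the shared core and the other ring are untouched.

Among the compounds with values here, with no measured step of this kind, the expected step of a 2.7-fold higher number from compound 1 to compound 4 (0.43 log units; beyond the scatter) is a modest weakening, close to the edge of the scatter rather than well beyond it. Compound 4 is accordingly estimated at 80 nM in this assay, with a range from 25 nM to 300 nM.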

Compound 4, half-maximal inhibitory concentration: 60 nM
Compound 4: middle estimate off by 1.3-fold (0.12 log units), on the high side; low and high end bracket the measured number.
By their numbers in this assay, from the lowest: compounds 1 and 4 (each within the scatter of the next); then compounds 2 and 3 (each within the scatter of the next).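

In this assay, going by these compounds alone, methyl in place of ethoxy on an aromatic carbon gives a 2.0-fold higher number from compound 1 to compound 4 (0.30 log units; within the scatter), the first step that changes a single place. At this position, para to a large group, ethoxy is therefore not required to keep the number in the range of compound 1, and the shorter, oxygen-free methyl group serves within the scatter. No supporting measurement bears on why the two groups read alike.

From the compounds shown here alone, what an amine, a carboxylic acid or a longer chain would do at this aromatic carbon remains open. Also open, going by these compounds, is how much the hydroxyl on the other ring contributes, since compound 2 and compound 3 each differ from compound 1 in more than one place.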